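A few compounds are considered here, and "the series" means these few. Any claim that something is new, unique, unknown or untested is made for them only; others in the source may bear on it.

Of the compounds shown here, two have been measured in a functional assay for antagonist activity at transient receptor potential cation channel subfamily V member 1 (Homo sapiens), read by FLIPR; on this read-out higher numbers stand for weaker inhibition and lower numbers for stronger inhibition. Compound 1 `Cc1cccnc1-c1ccc(C(=O)Nc2ccc(Cl)cc2)cc1` gives 1500 nM in this assay, while compound 2 `CCCOc1cccnc1-c1ccc(C(=O)Nc2ccc(C(C)(C)C)cc2)cc1` gives 62 nM. Compound 2 therefore stands at the lowest of the two numbers, and its gap to compound 1 lies well beyond the usual scatter of repeated measurements, so compound 2 is the stronger inhibitor of the pair.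

Compound 3 `CC(C)(C)c1ccc(NC(=O)c2ccc(-c3ncccc3-c3ncc[nH]3)cc2)cc1` has not yet been measured. It differs from compound 2 in one place: 1H-imidazol-2-yl in place of propoxy on an aromatic carbon. Nothing in the measured pair tells how this kind of exchange on an aromatic carbon affects the read-out, since compound 1 and compound 2 differ in several places at once.

For compound 3 a modest step toward a higher number is expected, of about a 2.4-fold higher number from compound 2 to compound 3 (0.38 log units; beyond the scatter). Compound 3 is thus estimated at 150 nM in this assay, with a plausible range from 40 nM to 600 nM.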

Compound 3, half-maximal inhibitory concentration: 3670 nM
Compound 3: middle estimate off by 24-fold (1.39 log units), on the low side; measured number above the stated range.
By their numbers in this assay, from the lowest: compound 2; then compound 1; then compound 3.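

In this assay, placing 1H-imidazol-2-yl instead of propoxy on this aromatic carbon, ortho to a large group and two atoms from the ring nitrogen, gives a 59-fold higher number from compound 2 to compound 3 (1.77 log units; beyond the scatter). Among these compounds, this is the first direct reading of a change at this position, and it shows that the group here matters greatly: the large step, well beyond the scatter, means much weaker inhibition for compound 3 than for compound 2. The data at hand give no measured reason for this loss.

On these data alone, whether the loss comes from the ring as a whole or from the hydrogen-bond donor it brings remains open. It is also unknown how a shorter methoxy, a longer butoxy chain or an amine would fare on this same carbon.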